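Pyrrolidinyl dithiocarbamate replacing the pyridylmethylamino group

The compounds below may be only part of what the source reports. "The series", "measured", "known", "first", "only" and "open" are said of these compounds alone.

Going by the values given here, compound 1 `CN(Cc1cccnc1)C(=S)SCc1ccc(C(=O)Nc2ccccc2N)cc1` stands at the top of the two measured members. In a functional assay on A-375 cells (Homo sapiens) for antiproliferative activity, read by CCK-8 assay, with a stated time of 72 h, tested at 8 uM (on this read-out lower numbers stand for a weaker effect and higher numbers for a stronger effect at the one concentration tested), compound 1 gives 83.8%, the highest of the two numbers recorded. Among the compounds with values here, its nearest neighbour is compound 2 `Nc1ccccc1NC(=O)c1ccc(CSC(=S)N2CCN(Cc3ccccc3)CC2)cc1`, which in this assay gives 29.3%, a gap beyond the usual scatter; the two structures differ in more than one place, so no single step is drawn between them. Compound 3 `Nc1ccccc1NC(=O)c1ccc(CSC(=S)N2CCCC2)cc1` is not yet measured. It differs from compound 1 in one place: pyrrolidin-1-yl in place of methyl((pyridin-3-yl)methyl)amino on a thiocarbonyl carbon. Within the data shown here, only one of two measured compounds reaches a strong read-out, and a move away from the substitution of compound 1 is expected to cost activity because compound 2 gives 29.3% at the same concentration. The expected step, a decrease beyond the scatter, is a number 33.8 percentage points lower from compound 1 to compound 3 (beyond the scatter). The estimate for compound 3 in this assay is 50%, with a range from 20% to 85%.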

Compound 3, a percentage reported as inhibition, at one concentration (the size of the read-out at that concentration, not a potency): 89.5%
Compound 3: middle estimate off by 39.5 percentage points, on the low side, outside the stated range (above it).
By their numbers in this assay, from the lowest: compound 2; then compounds 1 and 3 (each within the scatter of the next).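

In this assay the exchange on the thiocarbonyl carbon gives a number 5.7 percentage points higher from compound 1 to compound 3 (within the scatter) and so leaves the read-out unchanged within the scatter. At this position, the strong read-out of compound 1 therefore does not depend on methyl((pyridin-3-yl)methyl)amino and its six-membered aromatic ring: pyrrolidin-1-yl, with 5 heavy atoms in place of 9 and no aromatic ring, serves equally well. No measurement of any property of these groups accompanies this step, and the data offer no explanation for it.

Going by these compounds, whether a ring is needed here remains open, as does the effect of ring size and of a ring oxygen, which dimethylamino, piperidin-1-yl and morpholin-4-yl on the same carbon would address. A read-out at a single concentration also cannot separate compound 1 and compound 3 in potency.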